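This account rests on a few compounds, and the source may have more. Where it says the series, first, only, none or still open, it means among the compounds named here.

Compound 1 `CN(C(=O)C(C)(C)C)c1ccc2[nH]c(-c3n[nH]c4ccccc34)cc2n1` gives 4990 nM in a functional assay on HL-60 cells (Homo sapiens) for antiproliferative activity, read by MTT assay, with a stated time of 72 h; on this read-out lower numbers stand for stronger inhibition and higher numbers for weaker inhibition. Compound 2 `CN(C(=O)CCc1ccccc1)c1ccc2[nH]c(-c3n[nH]c4ccccc34)cc2n1` gives 4730 nM in this assay, the lowest of the two numbers, with a 1.1-fold lower number from compound 1 to compound 2 (0.02 log units; within the scatter). Compound 3 `CN(c1ccc2[nH]c(-c3n[nH]c4ccccc34)cc2n1)S(=O)(=O)c1ccc(Br)cc1` carries (4-bromophenyl)sulfonyl in place of phenethylcarbonyl on a nitrogen on an aromatic ring. Within the data shown here, the only measured step, a 1.1-fold lower number from compound 1 to compound 2 (0.02 log units; within the scatter), swapped one group on the carbonyl carbon and stayed within the scatter; no measured step exchanges the carbonyl itself for a sulfonyl, so the change is not anchored. Compound 3 is therefore expected to give 4500 nM (range 1500 nM to 14000 nM), which means an expected step of a 1.1-fold lower number from compound 2 to compound 3 (0.02 log units; within the scatter).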

Compound 3, half-maximal inhibitory concentration: 6240 nM
Estimate against measurement, compound 3: 1.4-fold (0.14 log units) below; low and high end bracket the measured number.
By their numbers in this assay, from the lowest: compounds 2, 1 and 3 (each within the scatter of the next).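

In this assay, the change from a carbonyl to a sulfonyl link on this nitrogen on an aromatic ring stays within the scatter, both against phenethylcarbonyl (a 1.3-fold higher number from compound 2 to compound 3 (0.12 log units; within the scatter)) and against (tert-butyl)carbonyl (a 1.3-fold higher number from compound 1 to compound 3 (0.10 log units; within the scatter)). The earlier compounds shown here had varied only the group on the carbonyl carbon, whereas these steps show no separation when the link itself is exchanged. No evidence on the reason for this is available. On these data alone, whether a free amine or a carboxylic acid at this place would give a number beyond the scatter remains open. So does the part played by the bromine.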